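This account rests on a few compounds, and the source may have more. Where it says the series, first, only, none or still open, it means among the compounds named here.

Measured so far in a functional assay on HeLa cells (Homo sapiens) for cytotoxicity, read by WST assay, with a stated time of 48 h; a higher number here means a weaker inhibitor, a lower number a stronger inhibitor:
compound 1, `COc1ccc(/C=C/C[C@H]2C[C@@H]([C@@H](O)c3ccccc3)CO[C@@H]2c2ccccc2)cc1`, 8300 nM
compound 2, `COc1ccc([C@H](O)[C@H]2CO[C@H](c3ccc(OC)c(OC)c3)[C@@H](C/C=C/c3ccc(OC)c(OC)c3)C2)cc1`, 46000 nM
compound 3, `COc1ccc(/C=C/C[C@H]2C[C@@H]([C@@H](O)c3ccc(OC)c(OC)c3)CO[C@@H]2c2ccc(OC)c(OC)c2)cc1OC`, 23800 nM

Compound 1 gives the lowest of the three numbers in this assay; compound 3 stands nearest to it and compound 2 furthest, and both gaps lie beyond the scatter.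

Compound 4, `O[C@@H](c1ccccc1)[C@H]1CO[C@H](c2ccccc2)[C@@H](C/C=C/c2ccccc2F)C1`, is still to be measured in this assay. Against compound 1 the change is 2-fluorophenyl in place of 4-methoxyphenyl on a double-bonded chain carbon bound to a double-bonded chain carbon. Within the data shown here, the only measured step that changes one place is a 1.9-fold lower number from compound 2 to compound 3 (0.29 log units; within the scatter), methoxy in place of hydrogen on an aromatic carbon, and it stayed within the scatter. Among the measured compounds shown here, it does not touch the 2-(4-methoxyphenyl)ethenyl arm, and no measured pair exchanges the aromatic ring on that arm, so the step to compound 4 has no direct precedent. Compound 2 and compound 3 differ from compound 1 in more than one place; their values show only that both sit higher than compound 1. Given the single methoxy step within the scatter, the expected step is a 1.1-fold higher number from compound 1 to compound 4 (0.04 log units; within the scatter), that is, none beyond the scatter. Compound 4 is therefore estimated at 9000 nM, with a range of 3000 nM to 30000 nM.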

Compound 4, half-maximal inhibitory concentration: 9730 nM
Beside the measured number, compound 4's estimate is 1.1-fold (0.03 log units) below it; the measured number falls inside the stated range.
By their numbers in this assay, from the lowest: compounds 1 and 4 (each within the scatter of the next); then compounds 3 and 2 (each within the scatter of the next).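

In this assay, among these compounds, the first measured change on the 2-(4-methoxyphenyl)ethenyl arm gives a 1.2-fold higher number from compound 1 to compound 4 (0.07 log units; within the scatter). At this place on a double-bonded chain carbon bound to a double-bonded chain carbon, 2-fluorophenyl can therefore stand in for 4-methoxyphenyl, with the methoxy oxygen gone and fluorine present, without a difference that can be told from the scatter in this pair. No evidence on the origin of this result is available.

Still open, going by these compounds, is whether a pyridine ring, an amine or a carboxylic acid on this arm, or a longer chain linking the arm to the shared core, would leave the number within the scatter too. Also open, on these data alone, is whether the same exchange of rings would give a step of similar size in compound 3.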